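The compounds below may be only part of what the source reports. "The series", "measured", "known", "first", "only" and "open" are said of these compounds alone.

Measured in a functional assay on ECa-109 cells for inhibition, with ECa-109 cell line (Homo sapiens) as the target, read by sulforhodamine B assay; on this read-out lower numbers stand for stronger inhibition and higher numbers for weaker inhibition:
- Compound 1 `O=C1C(Nc2ccc(I)cc2)=CC(=O)c2c1nc1n2[C@H]2OC[C@@H](O)[C@H]2OC1`: 2530 nM
- Compound 2 `O=C1C=C(N2CCC2)C(=O)c2c1nc1n2[C@H]2OC[C@@H](O)[C@H]2OC1`: > 16000 nM, a limit

Among the compounds with values here, compound 1 holds the only actual number in this assay. Compound 3 `O=C1C(NC2CCCC2)=CC(=O)c2c1nc1n2[C@H]2OC[C@@H](O)[C@H]2OC1` has not yet been measured. It carries cyclopentyl in place of 4-iodophenyl on an amine nitrogen. Within the data shown here, no measured step covers this change. Weaker inhibition is expected, a cautious reading that rests on compound 2, which also lacks 4-iodophenyl and is reported only as a limit, > 16000 nM. The expected change is a 2.4-fold higher number from compound 1 to compound 3 (0.38 log units; beyond the scatter). Compound 3 is estimated at 6000 nM, with an expected range of 2000 nM to 18000 nM.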

Compound 3, half-maximal inhibitory concentration: > 16000 nM
Compound 3 ended at the assay's limit; the forecaster's own chance of this, stated with the estimate: 20%; middle value at least 2.6-fold (0.42 log units) away from the limit.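

In this assay, within the data shown here, this position now has its first comparison in which only one place changes, something compound 2 did not provide: an at least 6.3-fold higher number from compound 1 to compound 3 (0.80 log units; beyond the scatter). On this amine nitrogen, cyclopentyl therefore does not retain the inhibition seen with 4-iodophenyl. The size of the step is only a minimum, because compound 3 is reported as a limit: the limit of > 16000 nM in this assay, at which 2 of the 3 values shown sit.

On these data alone, what remains open is whether the iodine or the aromatic ring accounts for the difference. Plain phenyl or 4-chlorophenyl on the same nitrogen would help separate the two.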